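The compounds below may be only part of what the source reports. "The series", "measured", "known", "first", "only" and "open" are said of these compounds alone.

For the measured compounds named here, three compounds sharing one core were taken into an ADME assay on HUVEC cells (Homo sapiens) for cytotoxicity, read by MTT assay, with a stated time of 72 h (on this read-out lower numbers stand for stronger inhibition and higher numbers for weaker inhibition), but only one gave a number. Compound 1 (`CCCn1ccnc1-c1cc(OC)c(OC)c(OC)c1`) stands at "not determined" (no result reported) in this assay and so offers no single figure to start from. Compound 2 (`COc1ccc(-n2ccnc2-c2cc(OC)c(OC)c(OC)c2)cc1[N+](=O)[O-]`) likewise stands at "not determined" (no result reported) and adds no figure either. Only compound 3 (`COc1cc(-c2nccn2-c2ccc3cc[nH]c3c2)cc(OC)c1OC`) has a measured value, at 40000 nM in the same test.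

The step now followed leads to compound 4 (`COc1cc(-c2nccn2-c2ccc(C)cc2)cc(OC)c1OC`), where 4-methylphenyl takes the place of propyl on an aromatic nitrogen (4-methylphenyl in place of propyl on an aromatic nitrogen). The group enters on an aromatic nitrogen of a five-membered aromatic ring with 2 nitrogen, and the propyl of compound 1 is gone. Going by the values given here, with no number for compound 1, the size of this step cannot be read from the data, and no measured pair shows what such a change does. Among the compounds with values here, compound 3 also carries an aromatic ring on that nitrogen, so its value (40000 nM) is the only guide, and no difference beyond the scatter from it is expected in this assay in either direction. Compound 4 is therefore expected to give about 30000 nM (estimated range 8000 nM to 100000 nM) when measured.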

Compound 4, half-maximal inhibitory concentration: > 100000 nM
Compound 4: only a limit was reported; the forecaster's own chance of this, stated with the estimate: 30%; middle value at least 3.3-fold (0.52 log units) away from the limit.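

No step can be read between compound 1 and compound 4, for compound 1 has no single figure in this assay and compound 4 is reported only as a limit: the limit of > 100000 nM in this assay, at which 1 of the 4 values shown sits.

The compounds shown leave open how propyl and 4-methylphenyl on the aromatic nitrogen compare in this assay, and what exact value compound 4 would take.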